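The source may report more compounds than this note shows. Statements on the series, on what has been measured and on what is new or still open speak of the compounds shown alone.

Compound 1: `COc1ccc(CCCCCCCCOc2ccc(C[S+]([O-])c3ccccc3)nc2/C=C/C(=O)O)cc1` — 37 nM in an assay for binding affinity to leukotriene B4 receptor 1 (Homo sapiens); a lower number here means a stronger inhibitor, a higher number a weaker inhibitor
Compound 2: `COc1ccc(CCCCCCCCOc2ccc(CSc3cccc(C(=O)O)c3)nc2/C=C/C(=O)O)cc1` — 80 nM in this assay
Compound 3: `COc1ccc(CCCCCCCCOc2ccc(CSc3cccc(N)c3)nc2/C=C/C(=O)O)cc1` — 34 nM in this assay

Compound 3 has the lowest of the three numbers in this assay. Its nearest neighbour is compound 1: a 1.1-fold lower number from compound 1 to compound 3 (0.04 log units; within the scatter). The gap to compound 2 is wider: a 2.4-fold lower number from compound 2 to compound 3 (0.37 log units; beyond the scatter), a change of amino in place of carboxy on an aromatic carbon. Compound 1 and compound 2 differ by a 2.2-fold higher number from compound 1 to compound 2 (0.33 log units; beyond the scatter).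

Compound 4 is `COc1ccc(CCCCCCCCOc2ccc(C[S+]([O-])c3cccc(N)c3)nc2/C=C/C(=O)O)cc1`. Relative to compound 3 it carries a group of 9 heavy atoms (6 carbon, 1 nitrogen, 1 oxygen, 1 sulfur; one six-membered aromatic ring of carbon only) in place of a group of 8 heavy atoms (6 carbon, 1 nitrogen, 1 sulfur; one six-membered aromatic ring of carbon only), on a saturated chain carbon bound to an aromatic carbon. Going by the values given here, the one measured step that bears on this change is the one between compound 1 and compound 3, where the sulfur-oxygen group of compound 1 is exchanged together with the amino for a plain ring, and that step stayed within the scatter. Among the compounds with values here, no measured pair isolates the oxidation of the sulfur alone, so the evidence is indirect. Given that compound 1 and compound 3 sit within the scatter of each other, compound 4 is expected to stay close to compound 3 in this assay, with a 1.0-fold higher number from compound 3 to compound 4 (0.01 log units; within the scatter) estimated as no step beyond the scatter. The estimate for compound 4 is 35 nM, expected within 15 nM to 80 nM.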

Compound 4, inhibition constant: 4.7 nM
Estimate against measurement, compound 4: 7.4-fold (0.87 log units) above; the whole stated range lies above it.
By their numbers in this assay, from the lowest: compound 4; then compounds 3 and 1 (each within the scatter of the next); then compound 2.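

In this assay, adding oxygen to the sulfur of the (3-aminophenyl)sulfanyl group gives a 7.2-fold lower number from compound 3 to compound 4 (0.86 log units; beyond the scatter), and amino in place of hydrogen on the aromatic carbon of the oxidised series gives a 7.9-fold lower number from compound 1 to compound 4 (0.90 log units; beyond the scatter), so each of the two changes counts at this saturated chain carbon bound to an aromatic carbon when the other is present. The earlier 1.1-fold lower number from compound 1 to compound 3 (0.04 log units; within the scatter), within the scatter, had hidden this, since that pair exchanges the two features against each other, while a 17-fold lower number from compound 2 to compound 4 (1.23 log units; beyond the scatter), which also changes two things, makes compound 4 the strongest inhibitor of the four. No measurement shown here accounts for the way these two changes combine.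

The compounds shown leave open whether a sulfone, with two oxygens on the sulfur, would extend or lose this effect, and whether a carboxylic acid on the ring would also do better with the sulfur-oxygen group than it does in compound 2. They also leave open whether an acetamide or a methylamine can stand in for the amino group.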